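The source may hold more compounds than are shown below. What is called first, only, known or untested is meant among the compounds shown, and "the series" means these compounds.

Compound 1 `Nc1cccc(-c2cn3c(-c4ccc(Cl)cc4)csc3n2)c1` carries a free amino group, and in a functional assay on L1210 cells (Mus musculus) for inhibition, read by cell counting, with a stated time of 2 days (a higher number here means a weaker inhibitor, a lower number a stronger inhibitor), compound 1 gives 22000 nM. Compound 2 `C=C(Br)C(=O)Nc1cccc(-c2cn3c(-c4ccc(Cl)cc4)csc3n2)c1` bears the (1-bromoethenyl)carbonyl group on that nitrogen; in this assay compound 2 gives 1900 nM. The change between them, (hydrogen in place of (1-bromoethenyl)carbonyl on a nitrogen on an aromatic ring), was accompanied by a 12-fold higher number from compound 2 to compound 1 (1.06 log units; beyond the scatter). Compound 3 `C=C(Br)C(=O)Nc1cccc(-c2cn3nc(-c4ccc(Cl)cc4)sc3n2)c1` holds the same amide on a second core; the difference between the two cores is not broken down here. In this assay compound 3 gives 1400 nM, and compound 2 lies within the usual scatter of it. Compound 4 `Nc1cccc(-c2cn3nc(-c4ccc(Cl)cc4)sc3n2)c1` follows compound 3 by the same change, (hydrogen in place of (1-bromoethenyl)carbonyl on a nitrogen on an aromatic ring), at a place described in identical words for both pairs. Among the compounds with values here, the step is expected to be a 12-fold higher number from compound 3 to compound 4 (1.08 log units; beyond the scatter), because a 12-fold higher number from compound 2 to compound 1 (1.06 log units; beyond the scatter) is the only precedent. Compound 4 is estimated at 17000 nM, expected between 7000 nM and 40000 nM.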

Compound 4, half-maximal inhibitory concentration: >= 250000 nM
Compound 4 was reported as a limit (the forecaster's own chance of this, stated with the estimate: 5%); at least 14-fold (1.16 log units) between middle value and limit.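

The change kept its direction on the second core, with an at least 170-fold higher number from compound 3 to compound 4 (2.25 log units; beyond the scatter) in this assay, so the number rose on both cores when the (1-bromoethenyl)carbonyl group gave way to hydrogen. Its size did not carry over from one core to the other: the same change on two cores in this assay, a 12-fold higher number (1.06 log units; beyond the scatter) from compound 2 to compound 1 and an at least 170-fold higher number (2.25 log units; beyond the scatter) from compound 3 to compound 4, at least 15-fold (1.18 log units) apart, beyond the scatter of two such steps Compound 4 is reported only as a limit, so the true size of its step remains unknown, and two cores set no rule for any other core: the limit of >= 250000 nM in this assay, at which 1 of the 4 values shown sits.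

The compounds shown leave open how an acetyl group or a propenoyl group without bromine on the same nitrogen would compare with the (1-bromoethenyl)carbonyl group on either core.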